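Shrinking the amine substituent: from acetamidopyrrolidine to azetidine

This account rests on a few compounds, and the source may have more. Where it says the series, first, only, none or still open, it means among the compounds named here.

The measured compounds:
compound 1, `O=C(CCc1ccc(C(F)(F)F)cc1)Nc1ccc2nc(N3CCCCC3)ccc2c1`, 12 nM;
compound 2, `O=C(CCc1ccc(C(F)(F)F)cc1)Nc1ccc2nc(N3CC4CCC3C4)ccc2c1`, 1 nM;
compound 3, `CC(=O)NC1CCN(c2ccc3cc(NC(=O)CCc4ccc(C(F)(F)F)cc4)ccc3n2)C1`, 5 nM.

In an assay on isolated protein for displacement of a labelled ligand from melanin-concentrating hormone receptor 1 (Homo sapiens) (on this read-out lower numbers stand for stronger inhibition and higher numbers for weaker inhibition), compound 3 stands second highest of the three numbers. Its nearest neighbour is compound 1, separated by a 2.4-fold lower number from compound 1 to compound 3 (0.38 log units; beyond the scatter), and its furthest is compound 2, separated by a 5.0-fold higher number from compound 2 to compound 3 (0.70 log units; beyond the scatter). The largest step seen so far is a 12-fold lower number from compound 1 to compound 2 (1.08 log units; beyond the scatter).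

Compound 4, `O=C(CCc1ccc(C(F)(F)F)cc1)Nc1ccc2nc(N3CCC3)ccc2c1`, has not been measured. The change from compound 3 is azetidin-1-yl in place of 3-acetamidopyrrolidin-1-yl on an aromatic carbon. For the measured compounds named here, no measured step removes this much from the amine side, so the expectation rests only on the fact that the two changes seen, from compound 1 to compound 2 and from compound 1 to compound 3, both enlarged the substituent and both lowered the number. A move in the opposite direction, to a smaller ring without the acetamido group, is therefore expected to raise the number in this assay modestly: a 4.0-fold higher number from compound 3 to compound 4 (0.60 log units; beyond the scatter). Compound 4 is thus estimated at 20 nM, with a range from 5 nM to 80 nM.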

Compound 4, half-maximal inhibitory concentration: 4 nM
Beside the measured number, compound 4's estimate is 5.0-fold (0.70 log units) above it, outside the stated range (below it).
By their numbers in this assay, from the lowest: compound 2; then compounds 4 and 3 (each within the scatter of the next); then compound 1.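

At this position, on an aromatic carbon next to the ring nitrogen, azetidin-1-yl and 3-acetamidopyrrolidin-1-yl cannot be told apart in this assay (a 1.3-fold lower number from compound 3 to compound 4 (0.10 log units; within the scatter)), so the acetamido group and the larger ring are not needed to reach this level. Azetidin-1-yl also improves on piperidin-1-yl (a 3.0-fold lower number from compound 1 to compound 4 (0.48 log units; beyond the scatter)) but falls short of the group in compound 2 (a 4.0-fold higher number from compound 2 to compound 4 (0.60 log units; beyond the scatter)), so the number does not follow substituent size across the four compounds, with compound 1 and compound 2 both going against any such trend. No available evidence accounts for these differences.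

The compounds shown leave open whether an open-chain amine such as dimethylamino would match azetidin-1-yl here. They also leave open what a hydroxyl or an acetamido group on the azetidine ring itself would do.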